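Methyl in place of hydroxy on an aromatic carbon

The compounds below may be only part of what the source reports. "The series", "measured", "known", "first", "only" and "open" are said of these compounds alone.

In a functional assay on PANC-1 cells (Homo sapiens) for inhibition, read by MTT assay, with a stated time of 24 h (on this read-out higher numbers stand for weaker inhibition and lower numbers for stronger inhibition), compound 2 (`CC1(C)[C@H]2CC[C@]1(C)N(Cc1cn(-c3ccccc3O)nn1)C(=O)C2`) gives 230 nM, within the scatter of compound 1 (`CC1(C)[C@H]2CC[C@]1(C)N(Cc1cn(-c3ccc(C#N)cc3)nn1)C(=O)C2`) at 250 nM. Compound 3 (`Cc1ccccc1-n1cc(CN2C(=O)C[C@@H]3CC[C@@]2(C)C3(C)C)nn1`) carries methyl in place of hydroxy on an aromatic carbon, ortho to a large group: methyl in place of hydroxy on an aromatic carbon. For the measured compounds named here, the only measured step is a 1.1-fold lower number from compound 1 to compound 2 (0.04 log units; within the scatter), a swap of 2-hydroxyphenyl for 4-cyanophenyl that stays within the scatter. Going by the values given here, no measured compound carries the methyl, so no direction can be argued. The expected change is a 1.0-fold higher number from compound 2 to compound 3 (0.02 log units; within the scatter), no step beyond the scatter. Compound 3 is estimated at 240 nM, with a range of 110 nM to 550 nM.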

Compound 3, half-maximal inhibitory concentration: 250 nM
Compound 3: the middle estimate sits 1.0-fold (0.02 log units) below what was measured, within the range that was stated.
By their numbers in this assay, from the lowest: compounds 2, 1 and 3 (each within the scatter of the next).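

In this assay, methyl in place of hydroxy on this aromatic carbon, ortho to a large group, gives a 1.1-fold higher number from compound 2 to compound 3 (0.04 log units; within the scatter), so a hydrogen-bond donor and acceptor at this place are not required to keep the number in this range. The 2-methylphenyl group also reads alike with the 4-cyanophenyl group, with no change at the digits printed from compound 1 to compound 3 (within the scatter). No evidence at hand accounts for this. The compounds shown leave open whether an amine or a carboxylic acid at this place, or a longer chain, would move the number beyond the scatter.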